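The source may report more compounds than this note shows. Statements on the series, on what has been measured and on what is new or still open speak of the compounds shown alone.

Measured compounds:
- compound 1 `Cn1c(=O)c2[nH]c(Cc3ccc(OCCCn4ccnc4)cc3)nc2n(C)c1=O`: > 10 nM
- compound 2 `Cn1c(=O)c2[nH]c(-c3ccc(OCCCCl)cc3)nc2n(C)c1=O`: > 10 nM
- compound 3 `Cn1c(=O)c2[nH]c(-c3ccc(OC4CCCC4)cc3)nc2n(C)c1=O`: 1 nM

In an assay on CHO cells for binding affinity to adenosine receptor A2b (Homo sapiens), with a stated time of 20 min (on this read-out higher numbers stand for weaker inhibition and lower numbers for stronger inhibition), compound 1 gives > 10 nM, which is a limit of the assay and not a number. Compound 1 therefore stands at the limit of > 10 nM in this assay, at which 2 of the 3 values shown sit, so only a weak upper bound on its binding is known. Compound 4 `Cn1c(=O)c2[nH]c(Cc3ccc(OCCCCl)cc3)nc2n(C)c1=O` differs from compound 1 by chloro in place of 1H-imidazol-1-yl on a saturated chain carbon, three bonds along the chain from an oxygen on an aromatic ring. Among the measured compounds shown here, one measured step touches the same chain: an at least 10-fold lower number from compound 2 to compound 3 (1.00 log units; beyond the scatter), which shows that the group on the aryl oxygen can move this read-out strongly. Compound 2 carries the same 3-chloropropyl group as compound 4 and in this assay compound 2 gives > 10 nM, again a limit. With both neighbours at the limit, no step beyond the scatter is expected, a step that the limit leaves unreadable from compound 1 to compound 4. Compound 4 is therefore estimated at 30 nM, within 10 nM to 300 nM, most likely reported as a limit.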

Compound 4, inhibition constant: > 10 nM
Compound 4: only a limit was reported; the forecaster's own chance of this, stated with the estimate: 70%; the middle value does not contradict the limit.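

Compound 1 and compound 4 each give only a limit, not a number, in this assay, and the step between them cannot be read: the limit of > 10 nM in this assay, at which 3 of the 4 values shown sit. From the compounds shown here alone, whether chloro in place of 1H-imidazol-1-yl changes binding at all stays open.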